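Shortening the amide chain: compound 2 to compound 3

A few compounds are considered here, and "the series" means these few. Any claim that something is new, unique, unknown or untested is made for them only; others in the source may bear on it.

Among the measured compounds shown here, compound 2 `CNC(=O)c1cc(C(=O)NCCC(C)C)cn(Cc2ccccc2)c1=O` is the only member of the series with a numerical solubility: in a physicochemical assay for solubility (a lower number here means a less soluble compound, a higher number a more soluble compound), compound 2 gives 10 ug/mL. Compound 1 `CNC(=O)c1cc(C(=O)NCCOC)cn(Cc2ccccc2)c1=O` carries a methoxyethyl chain on the same amide nitrogen, and in this assay compound 1 gives only a limit, >= 164 ug/mL. For the measured compounds named here, the one measured step, an at least 16-fold lower number from compound 1 to compound 2 (1.21 log units; beyond the scatter), is the sole guide, and its stated size rests on (the limit of >= 164 ug/mL in this assay, at which 1 of the 2 values shown sits). Compound 3 `CNC(=O)c1cc(C(=O)NC(C)C)cn(Cc2ccccc2)c1=O` keeps the core of compound 2 and differs only by isopropyl in place of isopentyl on an amide-type nitrogen. Going by the values given here, no measured step covers an exchange between two alkyl groups, so only the direction is borrowed: compound 2 sits low in this assay, and the smaller group enters. Compound 3 is therefore expected to be more soluble, with a 4.0-fold higher number from compound 2 to compound 3 (0.60 log units; beyond the scatter) as the estimated step. The estimate for compound 3 in this assay is 40 ug/mL, with a range from 15 ug/mL to 120 ug/mL.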

Compound 3, solubility: >= 136 ug/mL
Compound 3 gave a limit, no number (the forecaster's own chance of this, stated with the estimate: 10%); at least 3.4-fold (0.53 log units) between middle value and limit.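

The all-carbon exchange of isopropyl for isopentyl on the amide nitrogen, with no hydrogen-bond donors or acceptors on either side, gives a step beyond the scatter in this assay, with an at least 13-fold higher number from compound 2 to compound 3 (1.13 log units; beyond the scatter). Among the compounds shown here, the earlier step involved a chain carrying methoxy, so this is the first sign that the alkyl group alone can set a large difference at this position. Compound 3 gives >= 136 ug/mL, a limit and not a number, so a chain without methoxy can also reach a limit in this assay.

Compound 1 and compound 3 cannot be ordered, and the step between them cannot be read: the limit of >= 164 ug/mL in this assay, at which 1 of the 3 values shown sits. Open, from the compounds shown here alone, is how an isobutyl chain, or a chain ending in an amine, on this nitrogen would read in this assay.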